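Adding a 3-iodobenzyl group to an inactive bicyclic nucleoside

This account rests on a few compounds, and the source may have more. Where it says the series, first, only, none or still open, it means among the compounds named here.

Measured so far:
Compound 1 `Nc1ncnc2c1ncn2[C@@H]1O[C@@]2(CO)CO[C@@H]1[C@@H]2O`: > 100000 nM
Compound 2 `CNC(=O)[C@@]12CO[C@@H]([C@H](n3cnc4c(N)ncnc43)O1)[C@@H]2O`: > 100000 nM

In a functional assay for agonist activity at adenosine receptor A3 (Homo sapiens), with a stated time of 30 min (a lower number here means that less compound is needed, a higher number that more compound is needed for the effect), compound 2 is reported only as a limit, > 100000 nM. Compound 1 also sits at a limit in this assay, > 100000 nM, so the step that the two limits leave unreadable from compound 1 to compound 2 cannot be read. Compound 3 `CNC(=O)[C@@]12CO[C@@H]([C@H](n3cnc4c(NCc5cccc(I)c5)ncnc43)O1)[C@@H]2O` differs from compound 2 by 3-iodobenzyl in place of hydrogen on a nitrogen on an aromatic ring. Among the compounds with values here, no measured step touches this change; both values shown sit at the limit of > 100000 nM in this assay, at which 2 of the 2 values shown sit, which gives no direction. Compound 3 is therefore expected near 20000 nM, within 1000 nM to 100000 nM, with the step of an at least 5.0-fold lower number from compound 2 to compound 3 (0.69 log units; beyond the scatter) taken as an estimate only.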

Compound 3, half-maximal effective concentration: > 100000 nM
Compound 3 was reported as a limit; the forecaster's own chance of this, stated with the estimate: 45%; at least 5.0-fold (0.69 log units) between middle value and limit.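

In this assay compound 3 is again reported only as a limit, > 100000 nM, so the step from compound 2 to compound 3 cannot be read. The compounds shown leave open whether the 3-iodobenzyl group changes the response at all.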